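Hydrazide to phenylpiperazine amide on the shared core

The source may report more compounds than this note shows. Statements on the series, on what has been measured and on what is new or still open speak of the compounds shown alone.

The series shares a fused thiophene-bearing core with a sulfonylurea, read out in a functional assay on cells (Cancer cell lines, Homo sapiens) for inhibition, with a stated time of 48 h; on this read-out lower numbers stand for stronger inhibition of growth and higher numbers for weaker inhibition of growth. Compound 1 `O=C(Nc1sc2c(c1C(=O)NNc1ccccc1)CCCCC2)NS(=O)(=O)c1ccccc1` gives 15200 nM. Compound 2 `CN1CCN(C(=O)c2c(NC(=O)NS(=O)(=O)c3ccccc3)sc3c2CCCCC3)CC1` gives 31300 nM. Compound 3 `O=C(Nc1sc2c(c1C(=O)NNc1ccc(Cl)cc1)CCCCC2)NS(=O)(=O)c1ccccc1` gives 7500 nM, the lowest of the three numbers; its nearest neighbour is compound 1 and its furthest is compound 2, both steps beyond the scatter.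

The step to compound 4 `O=C(Nc1sc2c(c1C(=O)N1CCN(c3ccccc3)CC1)CCCCC2)NS(=O)(=O)c1ccccc1` is 4-phenylpiperazin-1-yl in place of ((4-chlorophenyl)amino)amino on a carbonyl carbon. For the measured compounds named here, two measured steps bear on it. Exchanging the hydrazide for a piperazine amide gave a 2.1-fold higher number from compound 1 to compound 2 (0.31 log units; beyond the scatter), and the reverse exchange, with the chloro substituent included, gave a 4.2-fold lower number from compound 2 to compound 3 (0.62 log units; beyond the scatter). The chloro substituent alone accounted for a 2.0-fold lower number from compound 1 to compound 3 (0.31 log units; beyond the scatter). Nothing measured separates a phenyl from a methyl on the piperazine nitrogen.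

Compound 4 is therefore expected to show a modest rise in this assay, a 2.7-fold higher number from compound 3 to compound 4 (0.43 log units; beyond the scatter), because compound 3 gives 7500 nM with the chloro substituent that compound 4 loses along with the hydrazide. The estimate for compound 4 is 20000 nM, with a range from 8000 nM to 50000 nM.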

Compound 4, concentration for 50% growth inhibition: 36200 nM
Beside the measured number, compound 4's estimate is 1.8-fold (0.26 log units) below it; the measured number falls inside the stated range.
By their numbers in this assay, from the lowest: compound 3; then compound 1; then compounds 2 and 4 (each within the scatter of the next).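

In this assay, phenyl in place of methyl on an amine nitrogen in a ring leaves the reading unresolved, a 1.2-fold higher number from compound 2 to compound 4 (0.06 log units; within the scatter), so compounds 2 and 4 stand level and the size of this substituent's group shows no effect across these two members. The piperazine amides in this pair therefore sit together on the high side of both hydrazides, with a 2.4-fold higher number from compound 1 to compound 4 (0.38 log units; beyond the scatter) and, larger, a 4.8-fold higher number from compound 3 to compound 4 (0.68 log units; beyond the scatter), so the exchange at the carbonyl carbon carries the difference, not the group on the piperazine nitrogen. Nothing available gives a reason for these steps.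

Still open, from the compounds shown here alone, is whether a chloro on the phenyl of compound 4 would lower the number as it does among the hydrazides. Also open, going by these compounds, is how a carboxylic acid or a primary amine on the piperazine nitrogen would read.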